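A trifluoroethoxy swap at the saturated chain carbon

The compounds below may be only part of what the source reports. "The series", "measured", "known", "first", "only" and "open" are said of these compounds alone.

In an ADME assay on microsomes from liver (Mus musculus) for metabolic stability, read by LC-MS, using NADPH, with stated times of 10 min and 30 min, tested at 1 uM (a lower number here means slower removal, a higher number faster removal of the compound), compound 1 (`COC(=O)C1=C(CN2CCC(F)(F)CC2)NC(c2nccs2)=NC1(C)c1ccc(F)cc1`) gives 88 mL/min/kg, compound 2 (`COC(=O)C1=C(CN2CCC(O)C2)NC(c2nccs2)=NC1(C)c1ccc(F)cc1`) gives 83 mL/min/kg and compound 3 (`COC(=O)C1=C(CN2CCC(C(F)(F)F)C2)NC(c2nccs2)=NC1(C)c1ccc(F)cc1`) gives 88 mL/min/kg. Compound 3 therefore stands level with compound 1 and within the scatter of compound 2, so the three numbers do not separate.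

Compound 4 (`COC(=O)C1=C(COCC(F)(F)F)NC(c2nccs2)=NC1(C)c1ccc(F)cc1`) has not yet been measured. It carries 2,2,2-trifluoroethoxy in place of 3-(trifluoromethyl)pyrrolidin-1-yl on a saturated chain carbon bound to a double-bonded ring carbon. The entering group has no ring, whereas every group measured at this place has one.

For the measured compounds named here, three measured steps bear on the change. Exchanging one ring group for another gave a 1.1-fold lower number from compound 1 to compound 2 (0.03 log units; within the scatter) and no change at the digits printed from compound 1 to compound 3 (within the scatter), while changing the substituent on the pyrrolidine ring gave a 1.1-fold higher number from compound 2 to compound 3 (0.03 log units; within the scatter). All three are small and within the scatter, but none of them tests an open chain at this place, so the evidence is only indirect.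

On this basis, no change beyond the scatter is expected in this assay, and the expected step is a 1.1-fold lower number from compound 3 to compound 4 (0.04 log units; within the scatter). For compound 4 the estimated clearance is 80 mL/min/kg, with an expected range of 45 mL/min/kg to 100 mL/min/kg.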

Compound 4, clearance: 81 mL/min/kg
For compound 4 the middle estimate is 1.0-fold (0.01 log units) below the measured one; measured number inside the range.
By their numbers in this assay, from the lowest: compounds 4, 2, 1 and 3 (each within the scatter of the next).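

In this assay, for the compounds shown here, 2,2,2-trifluoroethoxy is the first group at this place without a ring, and the open chain gives a result that stays within the scatter of all three ring-bearing compounds: a 1.1-fold lower number from compound 3 to compound 4 (0.04 log units; within the scatter) and a 1.0-fold lower number from compound 2 to compound 4 (0.01 log units; within the scatter) and a 1.1-fold lower number from compound 1 to compound 4 (0.04 log units; within the scatter). The earlier compounds had shown only that ring groups at this place do not separate, whereas these steps extend that to a smaller group with no ring and with oxygen rather than nitrogen bound to the saturated chain carbon, and none of the four compounds goes against this. Nothing given here accounts for this flat result at the position.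

The compounds shown leave open whether any group on the saturated chain carbon would move the number beyond the scatter, such as a carboxylic acid, a primary amine or a longer chain. They also leave open how far changes elsewhere would matter, such as a carboxylic acid in place of the methyl ester, since all four compounds share the same core and differ only at this place.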